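This account rests on a few compounds, and the source may have more. Where it says the series, first, only, none or still open, it means among the compounds named here.

Measured so far:
Compound 1, `CCOC1OC[C@@H](O)[C@H](O)[C@H]1O`, in an ADME assay on L6 cells (Rattus norvegicus) for cytotoxicity, read by MTT assay (a lower number here means that less compound is tolerated, a higher number that more compound is tolerated), compound 1 gives 50000000 nM.
Compound 2, `CCCS[C@@H]1OC[C@@H](O)[C@H](O)[C@H]1O`, in this assay compound 2 gives 200000 nM.

Compound 2 stands at the lower of the two numbers, so less of it is tolerated; compound 1 sits far higher, a gap well beyond the usual scatter. Compound 3, `CCS[C@@H]1OC[C@@H](O)[C@H](O)[C@H]1O`, has not yet been measured in this assay. It differs from compound 2 only by hydrogen in place of methyl on a saturated chain carbon, two bonds along the chain from a sulfur. Going by the values given here, no measured pair shows a change of this kind, so the size of the step rests on judgement alone: the shortening is small, and a change within the scatter, in either direction, is expected. Compound 3 is accordingly expected near 300000 nM, with a range of 100000 nM to 1500000 nM. The estimated step of a 1.5-fold higher number from compound 2 to compound 3 (0.18 log units; within the scatter) is expected to be modest.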

Compound 3, minimum cytotoxic concentration: 1000000 nM
Compound 3: middle estimate off by 3.3-fold (0.52 log units), on the low side; the range from low to high includes it.
By their numbers in this assay, from the lowest: compound 2; then compound 3; then compound 1.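

In this assay, going by these compounds alone, shortening propylsulfanyl to ethylsulfanyl gives a 5.0-fold higher number from compound 2 to compound 3 (0.70 log units; beyond the scatter) and this is the first pair of measured compounds that differ in one place. It shows that removing a single methyl at this position of the chain can move the tolerated concentration by more than the scatter. Nothing available explains this step. A single step cannot show whether the number keeps rising as the chain gets shorter. Methylsulfanyl, a longer chain such as butylsulfanyl, or an amine at the end of the chain could each test this.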